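The compounds below may be only part of what the source reports. "The series", "measured", "known", "first", "only" and "open" are said of these compounds alone.

Measured in a functional assay on DU-145 cells (Homo sapiens) for inhibition, read by trypan blue exclusion, with a stated time of 96 h; on this read-out higher numbers stand for weaker inhibition of growth and lower numbers for stronger inhibition of growth:

- compound 1 `O=C(O)c1ccc(C(=O)/C(=C\c2ccc(O)c([N+](=O)[O-])c2)SCc2ccc(Br)cc2)cc1`: 50000 nM
- compound 2 `O=C(O)c1ccc(C(=O)/C(=C\c2ccc(Br)cc2)SCc2ccc(F)cc2)cc1`: > 100000 nM (a limit of the assay, not a number)
- compound 3 `O=C(O)c1ccc(C(=O)/C(=C\c2ccc(F)c([N+](=O)[O-])c2)SCc2ccc(F)cc2)cc1`: 1000 nM

Among the compounds with values here, compound 3, at 1000 nM, has the lowest of the numbers so far. The nearest number is that of compound 1, at 50000 nM, a gap well beyond the scatter.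

Next in the series is compound 4 `O=C(O)c1ccc(C(=O)/C(=C\c2ccc(O)c([N+](=O)[O-])c2)SCc2ccc(F)cc2)cc1`. It keeps the core of compound 3 and differs at one site: hydroxy in place of fluoro on an aromatic carbon. The 4-fluoro-3-nitrophenyl group thus becomes 4-hydroxy-3-nitrophenyl.

Within the data shown here, only one measured step touches this group: an at least 100-fold lower number from compound 2 to compound 3 (2.00 log units; beyond the scatter). That large step shows the series responding strongly to the aryl group at this site in this assay, but it does not separate the fluoro from the nitro contribution. Among the measured compounds shown here, no measured step isolates hydroxy in place of fluoro.

The closest guide is compound 1, which carries the same 4-hydroxy-3-nitrophenyl group as compound 4, though it differs from compound 4 elsewhere. Compound 1 gives 50000 nM. On that value, a higher number than that of compound 3 is expected, beyond the scatter, with considerable uncertainty. The expected change is a 12-fold higher number from compound 3 to compound 4 (1.08 log units; beyond the scatter).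

The estimate for compound 4 is 12000 nM, with an expected range of 3000 nM to 60000 nM.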

Compound 4, concentration for 50% growth inhibition: > 100000 nM
Compound 4 gave a limit, no number (the forecaster's own chance of this, stated with the estimate: 10%); middle value at least 8.3-fold (0.92 log units) away from the limit.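

With the nitro group kept, hydroxy in place of fluoro in this assay gives an at least 100-fold higher number from compound 3 to compound 4 (2.00 log units; beyond the scatter), so the nitro group alone does not preserve the number of compound 3, and the group at this carbon decides much of the result. Compound 4 stands at a limit of the assay, > 100000 nM, and not at a number, so this step is only a floor, and the step that joins compound 4 to compound 2 cannot be read: the limit of > 100000 nM in this assay, at which 2 of the 4 values shown sit.

Fluoro in place of bromo on an aromatic carbon gives an at least 2.0-fold higher number from compound 1 to compound 4 (0.30 log units; that floor lies within the scatter), and since that floor lies within the scatter, this step gives no firm reading of the exchange.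

Still open, as far as these compounds go, is whether fluoro is needed at this carbon or whether chloro, methoxy or an amine would keep the number near that of compound 3. Also open is how much the nitro group contributes on its own, as no compound shown carries fluoro at this carbon without it.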